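Swapping a benzyl linker for a direct aryl amine

A few compounds are considered here, and "the series" means these few. Any claim that something is new, unique, unknown or untested is made for them only; others in the source may bear on it.

Of the compounds shown here, three have so far been tested in a functional assay on MCF7 cells (Homo sapiens) for inhibition, read by CCK-8 assay, with a stated time of 48 h; on this read-out lower numbers stand for stronger inhibition of growth and higher numbers for weaker inhibition of growth. Compound 1 `Cc1ccccc1Nc1nc(NCc2ccccc2)ncc1Cl` gives > 100000 nM, which is a limit of the assay rather than a number. Compound 2 `Cc1ccccc1Nc1nc(Nc2ccc(N3CCCCC3)cc2)ncc1Cl` likewise gives > 100000 nM, again a limit and not a measured figure. Compound 3 `COc1cccc(CNc2nc(Nc3ccc(N4CCN(C)CC4)cn3)ncc2Cl)c1` is the only one to yield an actual number, with 19500 nM in this assay. The other two values rest at the limit of > 100000 nM in this assay, at which 2 of the 3 values shown sit. Among the compounds with values here, compound 3 thus stands alone as the one compound with measurable growth inhibition.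

Compound 4 `COc1cccc(Nc2nc(Nc3ccc(N4CCN(C)CC4)cn3)ncc2Cl)c1` has not yet been measured. It differs from compound 3 in a single place: 3-methoxyphenyl in place of 3-methoxybenzyl on a nitrogen on an aromatic ring. Within the data shown here, no step between two measured compounds shows what this kind of change does here, so the expectation rests on compound 3 alone and is uncertain. Compound 4 is expected to give 9000 nM, within a range from 2000 nM to 50000 nM. The expected step of a 2.2-fold lower number from compound 3 to compound 4 (0.34 log units; beyond the scatter) is thus a modest gain in inhibition, only slightly beyond the usual scatter.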

Compound 4, concentration for 50% growth inhibition: 7540 nM
Compound 4: middle estimate off by 1.2-fold (0.08 log units), on the high side, within the range that was stated.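

Within the data shown here, replacing 3-methoxybenzyl with 3-methoxyphenyl on this nitrogen gives a 2.6-fold lower number from compound 3 to compound 4 (0.41 log units; beyond the scatter), the first direct reading of this change in this assay. With the rest of the molecule held the same, the ring can sit directly on the nitrogen without any loss of growth inhibition, and the number even improves modestly. No other step can be read here, because the remaining compounds rest at a limit of the assay rather than at a number: the limit of > 100000 nM in this assay, at which 2 of the 4 values shown sit.

From the compounds shown here alone, whether the same gain would hold for other groups on this nitrogen, such as an unsubstituted phenyl or a longer phenethyl chain, stays open. What this change does to the molecule, and so why the number falls, also stays open.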